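The source may hold more compounds than are shown below. What is called first, only, known or untested is meant among the compounds shown, and "the series" means these compounds.

Measured so far in a functional assay on UACC-62 cells (Homo sapiens) for inhibition, read by sulforhodamine B assay, with a stated time of 48 h; on this read-out lower numbers stand for stronger inhibition of growth and higher numbers for weaker inhibition of growth:
compound 1 `CC1=CC[C@H](C(C)(C)NC(=S)N/N=C/c2ccc(N(C)C)cc2)CC1` gives 45100 nM.
Compound 2 `CC1=CC[C@H](C(C)(C)NC(=S)N/N=C/c2ccc(F)cc2)CC1` gives only a limit, > 100000 nM.
Compound 3 `CC1=CC[C@H](C(C)(C)NC(=S)N/N=C/c2cccc([N+](=O)[O-])c2)CC1` likewise gives only a limit, > 100000 nM.

Compound 2 thus stands at the reporting limit of this assay, together with compound 3; only compound 1 returns a number. For the measured compounds named here, the one measured step that reaches compound 2, an at least 2.2-fold higher number from compound 1 to compound 2 (0.34 log units; beyond the scatter), already points toward weaker growth inhibition, and it can only be given as a lower bound because of the limit of > 100000 nM in this assay, at which 2 of the 3 values shown sit.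

Compound 4 `CC1=CC[C@H](C(C)(C)NC(=S)N/N=C/c2cccs2)CC1` differs from compound 2 by thiophen-2-yl in place of 4-fluorophenyl on a carbon with a double bond to nitrogen. Going by the values given here, no measured step touches this exchange of the aromatic part, so the expectation rests only on where compound 2 and compound 3 sit, both at the limit. A step of no clear size beyond the scatter is expected, an at least 1.1-fold lower number from compound 2 to compound 4 (0.04 log units; that floor lies within the scatter), with a real chance that compound 4 again returns only a limit. The estimate for compound 4 in this assay is 90000 nM, within a range from 30000 nM to 300000 nM.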

Compound 4, concentration for 50% growth inhibition: 2600 nM
For compound 4 the middle estimate is 35-fold (1.54 log units) above the measured one; measured number below the stated range.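

In this assay, the exchange at this place, on a carbon with a double bond to nitrogen, gives an at least 38-fold lower number from compound 2 to compound 4 (1.58 log units; beyond the scatter), so the aromatic part here can shift growth inhibition strongly. Compound 1, compound 2 and compound 3 all carry a six-membered aromatic ring of carbon only, and thiophen-2-yl shows that a five-membered aromatic ring with 1 hetero atom is tolerated at this place and gives a measurable number. The true size of the step remains unknown, and only its floor can be stated because compound 2 sits at a limit and not at a number: the limit of > 100000 nM in this assay, at which 2 of the 4 values shown sit.

The exchange alters ring size and hetero atom together, and the compounds shown do not separate the two. A furan-2-yl or a pyridin-2-yl group at the same place would bear on that question.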